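The compounds below may be only part of what the source reports. "The series", "measured", "known", "first", "only" and "open" are said of these compounds alone.

In an ADME assay on HT-29 cells (Homo sapiens) for cytotoxicity, read by MTT assay, with a stated time of 72 h (a higher number here means a weaker inhibitor, a lower number a stronger inhibitor), compound 1 `COc1ccc(C2=C(c3cc(OC)c(OC)c(OC)c3)C(=O)CC2O[SiH2]C(C)(C)C)cc1` gives > 100 ug/mL as a limit and not a number. From the compounds shown here alone, compound 2 `COc1cc(C2=C(c3cc(C)c(OC)c(C)c3)C(O)CC2=O)cc(OC)c1OC` also gives > 100 ug/mL as a limit, so its exact standing is unknown. Compound 3 `COc1cc(C2=C(c3cc(C)c(OC)c(C)c3)C(OC(C)=O)CC2=O)cc(OC)c1OC` changes hydroxy to acetoxy, with acetyl in place of hydrogen on an oxygen on a saturated carbon. Among the measured compounds shown here, no measured step guides this change. With compound 2 resting on (the limit of > 100 ug/mL in this assay, at which 2 of the 2 values shown sit), no step beyond the scatter is expected in this assay. The estimated step of a number no higher from compound 2 to compound 3 (the limit leaves the size open) is therefore small. Compound 3 is expected at 100 ug/mL, with an estimated range from 40 ug/mL to 200 ug/mL, and it may also return only a limit.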

Compound 3, half-maximal inhibitory concentration: > 100 ug/mL
Compound 3 ended at the assay's limit (the forecaster's own chance of this, stated with the estimate: 70%); the middle value lies on the limit itself.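

No step can be read from compound 2 to compound 3 in this assay, because both compounds return only a limit: the limit of > 100 ug/mL in this assay, at which 3 of the 3 values shown sit.

From the compounds shown here alone, whether changing hydroxy to acetoxy alters cytotoxicity at all, and how these compounds truly rank, stays open.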